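Fluoro to isopropyl on the pendant phenyl ring

A few compounds are considered here, and "the series" means these few. Any claim that something is new, unique, unknown or untested is made for them only; others in the source may bear on it.

Measured compounds:
Compound 1, `CC#CC(CC(=O)O)c1ccc(OCc2ccn3cc(-c4ccc(F)cc4)nc3c2)cc1`: 783 nM
Compound 2, `CC#CC(CC(=O)O)c1ccc(OCc2ccc3nc(-c4ccc(OC)cc4)cn3c2)cc1`: 47 nM
Compound 3, `CC#CC(CC(=O)O)c1ccc(OCc2ccc3nc(-c4ccccc4C)cn3c2)cc1`: 389 nM

In an assay on isolated protein for agonist activity at Free fatty acid receptor 1 (Homo sapiens) (a higher number here means that more compound is needed for the effect, a lower number that less compound is needed), compound 1 gives the highest of the three numbers. Compound 3 stands nearest, within the scatter of compound 1, so nothing can be said about their order; compound 2 stands furthest, a gap beyond the scatter. For the measured compounds named here, the only step between measured compounds, an 8.3-fold higher number from compound 2 to compound 3 (0.92 log units; beyond the scatter), concerns the group on the pendant phenyl ring, and it shows that changing that group can move the number modestly, but it sits on a core that differs from the shared core of compound 1 and compound 4.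

Compound 4, `CC#CC(CC(=O)O)c1ccc(OCc2ccn3cc(-c4ccc(C(C)C)cc4)nc3c2)cc1`, is not yet measured. It differs from compound 1 in one place: isopropyl in place of fluoro on an aromatic carbon. Going by the values given here, no measured pair shows this exact exchange, so the expectation rests only on the observation that the group on that ring matters, as the step from compound 2 to compound 3 shows. A step of modest size is therefore expected in this assay, in either direction, with a slight lean toward a lower number.

Compound 4 is estimated at 400 nM, within a range of 120 nM to 1500 nM, which corresponds to an expected step of a 2.0-fold lower number from compound 1 to compound 4 (0.29 log units; within the scatter).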

Compound 4, half-maximal effective concentration: 615 nM
Compound 4: middle estimate off by 1.5-fold (0.19 log units), on the low side; measured number inside the range.
By their numbers in this assay, from the lowest: compound 2; then compounds 3, 4 and 1 (each within the scatter of the next).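

On the shared core of compound 1 and compound 4, the exchange of fluoro for isopropyl, para to a large group on the pendant phenyl ring, gives a 1.3-fold lower number from compound 1 to compound 4 (0.10 log units; within the scatter) in this assay, so the read-out does not separate these two groups. Here the change from 4-fluorophenyl to 4-isopropylphenyl, the first exchange at this place on this core, leaves the two compounds within the scatter of each other, whereas the only earlier step, a different exchange on a different core, lay beyond it. Nothing in the data available explains this result.

The compounds shown leave open whether an amine, a nitrile or a trifluoromethyl group at this place on the shared core would give a number beyond the scatter of compound 1. They also leave open whether the 4-methoxyphenyl group of compound 2 or the 2-methylphenyl group of compound 3 would behave on the shared core as it does on its own.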